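A few compounds are considered here, and "the series" means these few. Any claim that something is new, unique, unknown or untested is made for them only; others in the source may bear on it.

Measured so far in an ADME assay on J774 cells (Mus musculus) for cytotoxicity; on this read-out higher numbers stand for an effect only at larger amounts of compound and lower numbers for an effect already at smaller amounts:

compound 1, `Cc1[nH]c2ccccc2c(=O)c1Cc1ccccc1`: > 40100 nM
compound 2, `CCCCC#Cc1c(C)[nH]c2ccc(OC)cc2c1=O`: > 36800 nM
compound 3, `CCCCC#Cc1c(C)[nH]c2ccccc2c1=O`: 8900 nM

Two of these three values are limits of this assay rather than numbers. For compound 1 the value > 40100 nM is such a limit (the limit of > 40100 nM in this assay, at which 1 of the 3 values shown sits). For compound 2 the value > 36800 nM is likewise a limit (the limit of > 36800 nM in this assay, at which 1 of the 3 values shown sits). Only compound 3 gives a number in this assay, 8900 nM.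

Compound 3 and compound 2 differ in one place: methoxy in place of hydrogen on an aromatic carbon. This change gave an at least 4.1-fold higher number from compound 3 to compound 2 (0.61 log units; beyond the scatter), so the compound carrying the methoxy shows an effect only at larger amounts.

Compound 4, `COc1cccc2[nH]c(C)c(Cc3ccccc3)c(=O)c12`, has not yet been measured in this assay. It differs from compound 1 in one place: methoxy in place of hydrogen on an aromatic carbon. The difference between the core of compound 1 and the core of compound 3 is not broken down here. The change leading to compound 4 is the same kind of change as the measured one, not the same: in the measured pair the methoxy sits meta to a fused ring and para to a fused ring, whereas in compound 4 it sits ortho to a fused ring and meta to a fused ring.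

Compound 1 already gives only a limit in this assay, > 40100 nM. The measured methoxy step raised the number. Compound 4 is therefore expected to sit at or beyond that limit, with an estimate of 70000 nM, between 30000 nM and 160000 nM, and most likely reported only as a limit. The expected step is a step that the limit leaves unreadable from compound 1 to compound 4, set beside the measured at least 4.1-fold higher number from compound 3 to compound 2 (0.61 log units; beyond the scatter).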

Compound 4, half-maximal effective concentration in the J774 assay: 11200 nM
For compound 4 the middle estimate is 6.3-fold (0.80 log units) above the measured one; the whole stated range lies above it.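

In the J774 assay methoxy in place of hydrogen on an aromatic carbon gave steps in opposite directions on the two cores: the same change on two cores in the J774 assay, an at least 4.1-fold higher number (0.61 log units; beyond the scatter) from compound 3 to compound 2 and an at least 3.5-fold lower number (0.55 log units; beyond the scatter) from compound 1 to compound 4, at least 14-fold (1.17 log units) apart, beyond the scatter of two such steps. On the core of compound 1 the change gave an at least 3.5-fold lower number from compound 1 to compound 4 (0.55 log units; beyond the scatter), so here the compound carrying the methoxy shows an effect already at smaller amounts, and the size of this step is only a floor, as compound 1 gives just a limit of the assay: the limit of > 40100 nM in the J774 assay, at which 1 of the 4 values shown sits. This does not show what reverses the direction, since the pairs differ in their cores and also in where the methoxy sits, ortho to a fused ring and meta to a fused ring in compound 4 but meta to a fused ring and para to a fused ring in compound 2, and these compounds cannot separate those two differences.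

Open, as far as these compounds go, is whether a methoxy at the place it holds in compound 4 would give the same direction on the core of compound 3, and whether a hydroxyl or an ethoxy in that place would follow the methoxy. In a physicochemical assay for solubility, read by HPLC, at pH 7.4 (on this read-out lower numbers stand for lower solubility and higher numbers for higher solubility), compound 1 gives 10000 nM. In the physicochemical assay compound 4 gives > 20000 nM, which is a limit of the assay and not a number. For the compounds shown here, also open is how far the change really moves the number in the physicochemical assay, where the only reading is an at least 2.0-fold higher number from compound 1 to compound 4 (0.30 log units; that floor lies within the scatter).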